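Removing a Hydroxy Group from a Long-Chain Amide

The compounds below may be only part of what the source reports. "The series", "measured", "known", "first", "only" and "open" are said of these compounds alone.

Three measured compounds share one core and differ only in their long chain. Compound 1 `CCCCCC[C@@H](O)C/C=C\CCCCCCCCSCCC(=O)NCc1ccc(O)c(OC)c1` carries a hydroxy group on that chain. In an assay on HEK293 cells for antagonist activity at transient receptor potential cation channel subfamily V member 2 (Rattus norvegicus), read by fluorescence and calcium flux, with a stated time of 5 min (a higher number here means a weaker inhibitor, a lower number a stronger inhibitor), compound 1 gives only a limit, > 10000 nM. Compound 2 `CCCCCCCC/C=C\CCCCCCCCCCCC(=O)NCc1ccc(O)c(OC)c1` ends in a dec-1-en-1-yl group, and in this assay compound 2 gives 490 nM. Compound 3 `CCCCCCCCCCCCCCCC(=O)NCc1ccc(O)c(OC)c1` has a saturated chain. In this assay compound 3 also reaches only a limit, > 10000 nM. The single measured step between neighbours is an at least 20-fold higher number from compound 2 to compound 3 (1.30 log units; beyond the scatter); together with the limit of > 10000 nM in this assay, at which 2 of the 3 values shown sit, that is all the shown data say about the chain end.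

Compound 4 `CCCCCCCC/C=C\CCCCCCCCSCCC(=O)NCc1ccc(O)c(OC)c1` is compound 1 with one change: hydrogen in place of hydroxy on a saturated chain carbon bound to two saturated chain carbons. Compound 1 stands at the limit, so its own value is not a number. Among the compounds with values here, no measured step touches a hydroxy group, so the size of the change from compound 1 to compound 4 cannot be read from the measured pairs. Compound 4 does keep the dec-1-en-1-yl end that compound 2 carries while giving 490 nM, and the step of an at least 20-fold higher number from compound 2 to compound 3 (1.30 log units; beyond the scatter) shows that end to matter. Compound 4 is therefore expected to give a number rather than a limit, estimated at 1500 nM with a range from 300 nM to 10000 nM. This estimate for compound 4 means an expected step of an at least 6.6-fold lower number from compound 1 to compound 4 (0.82 log units; beyond the scatter).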

Compound 4, half-maximal inhibitory concentration: 2500 nM
The estimate for compound 4 lay 1.7-fold (0.22 log units) below the measured number; measured number inside the range.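

The step gives the hydroxy group its first measured effect in this assay: with hydrogen in its place on a saturated chain carbon bound to two saturated chain carbons, there is an at least 4.0-fold lower number from compound 1 to compound 4 (0.60 log units; beyond the scatter). The earlier compounds shown here showed only that the dec-1-en-1-yl end matters, whereas this pair shows that a single oxygen on that end, as in 4-hydroxydec-1-en-1-yl, is enough to separate a measurable inhibitor from one that gives no number. The step is only a minimum, and its true size stays unknown, because compound 1 rests at a limit rather than a number: the limit of > 10000 nM in this assay, at which 2 of the 4 values shown sit.

The compounds shown leave open whether the same drop would follow a methoxy group, a ketone carbonyl or an amine on this carbon, and whether the mirror-image arrangement of the hydroxy group would behave like compound 1. They also leave open whether a hydroxy group elsewhere along the chain, or on a longer chain, would have a similar effect.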